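This account rests on a few compounds, and the source may have more. Where it says the series, first, only, none or still open, it means among the compounds named here.

Compound 1 `Cc1cc(Cl)ccc1C(=O)Nc1ccc(Cl)c(-c2nnc3c(Cl)cccn23)c1`: in a functional assay on T47D cells (Homo sapiens) for antiproliferative activity, read by MTT assay, with a stated time of 72 h (on this read-out higher numbers stand for weaker inhibition and lower numbers for stronger inhibition), compound 1 gives > 100000 nM, which is a limit of the assay and not a number.
Compound 2 `CS(=O)(=O)c1ccc(C(=O)Nc2ccc(Cl)c(-c3nnc4c(Cl)cccn34)c2)c(Cl)c1`: in this assay compound 2 gives > 100000 nM, again only a limit.
Compound 3 `O=C(Nc1ccc(Cl)c(-c2nnc3c(Cl)cccn23)c1)c1cccnc1Cl`: in this assay compound 3 gives > 100000 nM, also a limit.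

Compound 3 therefore stands where every measured value in this series sits, at the limit of > 100000 nM in this assay, at which 3 of the 3 values shown sit. For the measured compounds named here, the one step with a single structural change, a step that the two limits leave unreadable from compound 1 to compound 3, joins two limits and its size cannot be read. Compound 4 `O=C(Nc1ccc(Cl)c(-c2nnc3c(Cl)cccn23)c1)c1ccccc1Cl` differs from compound 3 by 2-chlorophenyl in place of 2-chloropyridin-3-yl on a carbonyl carbon. Going by the values given here, the only measured step that bears on this change is the unreadable one from compound 1 to compound 3, so no direction and no size can be taken from it, and nothing among the measured compounds shows a value beyond the limit. Compound 4 is thus expected to stay where compound 3 stands, with an expected step that the limit leaves unreadable from compound 3 to compound 4 in this assay. The estimate for compound 4 is 150000 nM, with a range from 30000 nM to 1000000 nM, most likely reported as a limit again.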

Compound 4, half-maximal inhibitory concentration: 83800 nM
Compound 4: middle estimate off by 1.8-fold (0.25 log units), on the high side; the measured number falls inside the stated range.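

In this assay compound 4 is the only compound shown that gives a number and not a limit: the limit of > 100000 nM in this assay, at which 3 of the 4 values shown sit. With 2-chlorophenyl in place of 2-chloropyridin-3-yl on the carbonyl carbon there is an at least 1.1-fold lower number from compound 3 to compound 4 (0.07 log units; that floor lies within the scatter), with hydrogen in place of methylsulfonyl on an aromatic carbon there is an at least 1.1-fold lower number from compound 2 to compound 4 (0.07 log units; that floor lies within the scatter), and with 2-chlorophenyl in place of 4-chloro-2-methylphenyl there is an at least 1.1-fold lower number from compound 1 to compound 4 (0.07 log units; that floor lies within the scatter). On these data alone, these are floors only, so the true size of each step stays unknown, and the steps joining two limits cannot be read.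

As far as these compounds go, it remains open how far the number would move with other groups on the carbonyl carbon, such as an unsubstituted phenyl or a piperidine. From the compounds shown here alone, it is also open whether a methoxy group or a nitrile in place of the chlorine on the phenyl ring would shift it.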